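The compounds below may be only part of what the source reports. "The series", "measured", "known", "first", "only" and "open" are said of these compounds alone.

Measured compounds:
compound 1 `CSc1c(F)cccc1NCC1=NCCN1`: 148 nM
compound 2 `CS(=O)(=O)c1c(F)cccc1NCC1=NCCN1`: 550 nM
compound 3 `CSc1ccc(C(F)(F)F)cc1NCC1=NCCN1`: 589 nM

All three values come from an assay for binding affinity to Alpha-1A adrenergic receptor (Homo sapiens), read by radioligand binding; a higher number here means a weaker inhibitor, a lower number a stronger inhibitor. Within the data shown here, the only single-point step among them runs from compound 1 to compound 2, where the change is methylsulfonyl in place of methylsulfanyl on an aromatic carbon; it gives a 3.7-fold higher number from compound 1 to compound 2 (0.57 log units; beyond the scatter). Compound 3 carries a different core, and the difference between the two cores is not broken down here. The values of compound 2 and compound 3 lie within the scatter of each other, so nothing is read from that pair.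

Compound 4 `CS(=O)(=O)c1ccc(C(F)(F)F)cc1NCC1=NCCN1` is not yet measured. It differs from compound 3 by methylsulfonyl in place of methylsulfanyl on an aromatic carbon. Among the measured compounds shown here, this is the same kind of change as the one from compound 1 to compound 2, but the surroundings differ: in compound 1 the site is ortho to a fluoro group, in compound 3 it is para to a trifluoromethyl group. For compound 4 a step of a 3.4-fold higher number from compound 3 to compound 4 (0.53 log units; beyond the scatter) is expected in this assay, resting on the step of a 3.7-fold higher number from compound 1 to compound 2 (0.57 log units; beyond the scatter) seen in compound 1 and compound 2, with added uncertainty from the changed surroundings. Compound 4 is estimated at 2000 nM, with a range of 800 nM to 5500 nM.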

Compound 4, inhibition constant: < 12600 nM
Compound 4: a limit, no number; the forecaster's own chance of this, stated with the estimate: 5%; the middle value does not contradict the limit.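

In this assay compound 4 gives < 12600 nM, which is a limit and not a number. The step from compound 3 to compound 4 therefore cannot be read: the limit of < 12600 nM in this assay, at which 1 of the 4 values shown sits. The compounds shown leave open whether methylsulfonyl in place of methylsulfanyl, para to a trifluoromethyl group, matches the step seen elsewhere, a 3.7-fold higher number from compound 1 to compound 2 (0.57 log units; beyond the scatter).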